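Working notes: aryl swap at the weak end of the series

A few compounds are considered here, and "the series" means these few. Any claim that something is new, unique, unknown or untested is made for them only; others in the source may bear on it.

compound 1 `Cc1cc(-c2c(C)nn(C)c2C)ccc1-c1nnc(N(C)Cc2ccc3ncc(-c4cnn(C)c4)n3c2)o1`: 12600 nM
compound 2 `Cc1cc(-c2c(C)nn(C)c2C)cnc1-c1nnc(N(C)Cc2ccc3ncc(-c4cnn(CCN(C)C)c4)n3c2)o1`: > 31600 nM

In an assay on COS-7 cells for inhibition of tyrosine-protein kinase receptor TYRO3 (Homo sapiens), read by ELISA, with a stated time of 1 h (on this read-out higher numbers stand for weaker inhibition and lower numbers for stronger inhibition), compound 1 gives 12600 nM. For compound 2 the assay reports only a limit, > 31600 nM, not a number (the limit of > 31600 nM in this assay, at which 1 of the 2 values shown sits). Compound 3 `Cc1cc(-c2c(C)nn(C)c2C)cnc1-c1nnc(N(C)Cc2ccc3ncc(-c4ccc(CN(C)C)cn4)n3c2)o1` is not yet measured; it carries 5-((dimethylamino)methyl)pyridin-2-yl in place of 1-(2-(dimethylamino)ethyl)-1H-pyrazol-4-yl on an aromatic carbon, 5-((dimethylamino)methyl)pyridin-2-yl in place of 1-(2-(dimethylamino)ethyl)-1H-pyrazol-4-yl on an aromatic carbon. Among the compounds with values here, no step between measured compounds exists here, so no direction is supported; an at least 1.0-fold lower number from compound 2 to compound 3 (0.02 log units; that floor lies within the scatter) is the expected change, none beyond the scatter. Compound 3 is accordingly estimated at 30000 nM, with a range from 8000 nM to 100000 nM, and another limit is considered likely.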

Compound 3, half-maximal inhibitory concentration: > 31600 nM
Compound 3 was reported as a limit; the forecaster's own chance of this, stated with the estimate: 60%; at least 1.0-fold (0.02 log units) between middle value and limit.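

Compound 2 and compound 3 are both reported only as limits, so no step between them can be read: the limit of > 31600 nM in this assay, at which 2 of the 3 values shown sit.

As far as these compounds go, whether 5-((dimethylamino)methyl)pyridin-2-yl differs from 1-(2-(dimethylamino)ethyl)-1H-pyrazol-4-yl at this position remains open.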